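Removing a Methyl Group on a Six-Ring Fused Core

The compounds below may be only part of what the source reports. "The series", "measured", "known", "first", "only" and "open" are said of these compounds alone.

Compound 1 `Cc1oc2c3c(ccc2c(=O)c1C)OC[C@H]1[C@@H]3c2c(ccc(C(=O)c3ccccc3)c2O)OC1(C)C` in a functional assay on MCF7 cells (Homo sapiens) for cytotoxicity, read by MTT assay (on this read-out lower numbers stand for stronger inhibition and higher numbers for weaker inhibition), reaches only a limit of the assay, > 100000 nM.
Compound 2 `Cc1coc2c3c(ccc2c1=O)OC[C@H]1[C@@H]3c2c(ccc(C(=O)c3ccccc3)c2O)OC1(C)C` in this assay gives 6240 nM.
Compound 3 `Cc1oc2c3c(ccc2c(=O)c1C)OC[C@H]1[C@@H]3c2ccc3ccccc3c2OC1(C)C` in this assay reaches only a limit of the assay, > 100000 nM.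

From compound 1 to compound 2 the change is hydrogen in place of methyl on an aromatic carbon, and it brought an at least 16-fold lower number from compound 1 to compound 2 (1.20 log units; beyond the scatter), with the starting point being (the limit of > 100000 nM in this assay, at which 2 of the 3 values shown sit). Compound 4 `Cc1coc2c3c(ccc2c1=O)OC[C@H]1[C@@H]3c2ccc3ccccc3c2OC1(C)C` carries the same kind of change on the core of compound 3, (hydrogen in place of methyl on an aromatic carbon); the place differs in that the ring is part of a fused or bridged system of five rings in compound 1 and of six rings in compound 3. How the two cores differ is not broken down here. Because compound 3 sits at the limit of > 100000 nM in this assay, at which 2 of the 3 values shown sit, the step is expected to be an at least 3.3-fold lower number from compound 3 to compound 4 (0.52 log units; beyond the scatter), so compound 4 is estimated at 30000 nM.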

Compound 4, half-maximal inhibitory concentration: > 100000 nM
Compound 4: only a limit was reported; the forecaster's own chance of this, stated with the estimate: 40%; middle value at least 3.3-fold (0.52 log units) from the limit.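

The step from compound 3 to compound 4 cannot be read, because both compounds sit at the same limit: the limit of > 100000 nM in this assay, at which 3 of the 4 values shown sit.

From the compounds shown here alone, whether hydrogen in place of methyl changes anything on the core of compound 3, as it did on the core of compound 1, stays open.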